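A few compounds are considered here, and "the series" means these few. Any claim that something is new, unique, unknown or untested is made for them only; others in the source may bear on it.

Working notes on the series. Compound 1 `C=C/C=C\[C@H](C)[C@H](OC(N)=O)[C@@H](C)[C@H](O)[C@@H](C)C/C(C)=C\[C@H](C)[C@@H](O)[C@@H](C)/C=C\CCc1ccc(C)c(F)c1` gives 4000 nM in a functional assay on MCF7 cells (Homo sapiens) for cytotoxicity; a higher number here means a weaker inhibitor, a lower number a stronger inhibitor; compound 2 `C=C/C=C\[C@H](C)[C@H](OC(N)=O)[C@@H](C)[C@H](O)[C@@H](C)C/C(C)=C\[C@H](C)[C@@H](O)[C@@H](C)/C=C\CCc1cc(F)cc(F)c1` gives 2000 nM, and the step of a 2.0-fold lower number from compound 1 to compound 2 (0.30 log units; within the scatter) is within the scatter, so the two numbers cannot be ordered. Compound 3 `C=C/C=C\[C@H](C)[C@H](OC(N)=O)[C@@H](C)[C@H](O)[C@@H](C)C/C(C)=C\[C@H](C)[C@@H](O)[C@@H](C)/C=C\CCc1cc(O)cc(O)c1` differs from compound 1 as follows: 3,5-dihydroxyphenyl in place of 3-fluoro-4-methylphenyl on a saturated chain carbon, two bonds along the chain from a double-bonded chain carbon. Going by the values given here, the only measured step touching the same aromatic group is a 2.0-fold lower number from compound 1 to compound 2 (0.30 log units; within the scatter), which did not leave the scatter, and no step toward hydroxyl groups exists. For compound 3 a step of no change at the digits printed from compound 1 to compound 3 (within the scatter) is expected, and the expected value is 4000 nM, range 1000 nM to 16000 nM.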

Compound 3, half-maximal inhibitory concentration: > 1000 nM
Compound 3 ended at the assay's limit; the forecaster's own chance of this, stated with the estimate: 10%; the middle value lies beyond the limit too.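

Compound 3 reads > 1000 nM, which is a limit and not a number. The steps to compound 3 from compound 1 and compound 2 cannot be read. The compounds shown leave open how 3,5-dihydroxyphenyl compares with either fluorinated aromatic group.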